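This account rests on a few compounds, and the source may have more. Where it says the series, first, only, none or still open, it means among the compounds named here.

Working notes on the series. Compound 1 `COc1ccc(C2=C(c3ccc(SC)cc3)CC3CCCN3C2=O)cc1Br` is the reference point. Going by the values given here, in a functional assay on A498 cells (Homo sapiens) for cytotoxicity (a higher number here means a weaker inhibitor of growth, a lower number a stronger inhibitor of growth), compound 1 gives 600 nM, the highest of the two numbers measured so far. Compound 2 `CSc1ccc(C2=C(c3ccc(F)c(F)c3)C(=O)N3CCCC3C2)cc1` gives 100 nM in this assay. Among the compounds with values here, the only step on record is a 6.0-fold lower number from compound 1 to compound 2 (0.78 log units; beyond the scatter), modest in size but beyond the scatter.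

Compound 3 `CSc1ccc(C2=C(c3ccc(C)cc3)C(=O)N3CCCC3C2)cc1` has not yet been measured. Its difference from compound 1 is 4-methylphenyl in place of 3-bromo-4-methoxyphenyl on a double-bonded ring carbon. Within the data shown here, the single measured step bears on this only loosely, since it exchanged the same 3-bromo-4-methoxyphenyl for 3,4-difluorophenyl rather than for 4-methylphenyl, and nothing else has been measured at that place. On that one precedent a lower number in this assay is expected for compound 3, with wide uncertainty. The expected step is roughly a 2.4-fold lower number from compound 1 to compound 3 (0.38 log units; beyond the scatter). The estimate for compound 3 in this assay is 250 nM, with a range from 80 nM to 800 nM.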

Compound 3, concentration for 50% growth inhibition: 4000 nM
Compound 3: the middle estimate sits 16-fold (1.20 log units) below what was measured, and the stated range ends below it.
By their numbers in this assay, from the lowest: compound 2; then compound 1; then compound 3.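

On the double-bonded ring carbon, replacing 3-bromo-4-methoxyphenyl does not move the number in one fixed direction: with 4-methylphenyl in this assay there is a 6.7-fold higher number from compound 1 to compound 3 (0.82 log units; beyond the scatter), opposite to the change seen with 3,4-difluorophenyl. The two replacements themselves are far apart, with a 40-fold higher number from compound 2 to compound 3 (1.60 log units; beyond the scatter), so this place separates substituted phenyl groups strongly, and compound 3 is the weakest inhibitor of growth of the three. No measurement available here accounts for this difference between the groups.

Still open, from the compounds shown here alone, is where a phenyl group carrying an amine or a carboxylic acid, or a 4-chlorophenyl group, would fall at this place. Also open, going by these compounds, is whether the same order of groups holds when the 4-(methylsulfanyl)phenyl group is exchanged.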